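Arylamide Exchange on a Vitamin D Receptor Agonist Series

This account rests on a few compounds, and the source may have more. Where it says the series, first, only, none or still open, it means among the compounds named here.

Measured so far:
compound 1, `CCn1c(C(=O)NCCCN(C)C)ccc1C(CC)(CC)c1ccc(OCC(=O)C(C)(C)C)c(C)c1`, 96 nM
compound 2, `CCn1c(C(=O)N(C)c2ccccc2)ccc1C(CC)(CC)c1ccc(OCC(=O)C(C)(C)C)c(C)c1`, 18500 nM
compound 3, `CCn1c(C(=O)NCCCN(C)C)ccc1C(CC)(CC)c1ccc(OCC(O)C(C)(C)C)c(C)c1`, 37 nM

Compound 3 stands lowest of the three numbers in an assay on HL-60 cells for agonist activity at vitamin D3 receptor (Homo sapiens), read by microscopy, with a stated time of 96 h; on this read-out lower numbers stand for an effect already at smaller amounts and higher numbers for an effect only at larger amounts of compound; its nearest neighbour is compound 1, with a 2.6-fold lower number from compound 1 to compound 3 (0.41 log units; beyond the scatter), and compound 2 lies far behind both. The unmeasured compound 4 is `CCOc1ccc(NC(=O)c2ccc(C(CC)(CC)c3ccc(OCC(O)C(C)(C)C)c(C)c3)n2CC)cc1`. It keeps the 1-hydroxy-2,2-dimethylpropyl side of compound 3 and differs only at the amide: 4-ethoxyphenyl in place of 3-(dimethylamino)propyl on an amide-type nitrogen. The amide hydrogen stays in place, unlike the methyl(phenyl)amino group of compound 2.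

Going by the values given here, one measured step bears directly on this change. Replacing the (3-(dimethylamino)propyl)amino group with methyl(phenyl)amino gave a 190-fold higher number from compound 1 to compound 2 (2.28 log units; beyond the scatter), a very large loss. Compound 4 makes a comparable exchange of the dimethylaminopropyl chain for an aromatic ring, though with the amide hydrogen retained and an ethoxy group added, so the size of that step is only a rough guide. Among the compounds with values here, a large move toward higher numbers is nevertheless expected, probably smaller than the one from compound 1 to compound 2 because the step of a 190-fold higher number from compound 1 to compound 2 (2.28 log units; beyond the scatter) also altered the amide hydrogen.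

Compound 4 is therefore expected at 1200 nM, within 200 nM to 8000 nM, a step of a 32-fold higher number from compound 3 to compound 4 (1.51 log units; beyond the scatter).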

Compound 4, half-maximal effective concentration: 630 nM
Compound 4: middle estimate off by 1.9-fold (0.28 log units), on the high side; low and high end bracket the measured number.
By their numbers in this assay, from the lowest: compound 3; then compound 1; then compound 4; then compound 2.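

With the amide hydrogen kept and the 1-hydroxy-2,2-dimethylpropyl side unchanged, exchanging 3-(dimethylamino)propyl for 4-ethoxyphenyl on the amide-type nitrogen still gives a 17-fold higher number from compound 3 to compound 4 (1.23 log units; beyond the scatter) in this assay, so a retained amide hydrogen is not enough on its own to hold the number near that of compound 3. Together with a 190-fold higher number from compound 1 to compound 2 (2.28 log units; beyond the scatter), this means that both exchanges at this position that replace the 3-(dimethylamino)propyl chain with an aromatic ring move to a much higher number, one on the (tert-butyl)carbonyl side and one on the 1-hydroxy-2,2-dimethylpropyl side, and no compound shown goes against this. No available measurement explains the loss.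

The compounds shown leave open whether the dimethylamino nitrogen, the propyl chain or the absence of an aromatic ring matters most, which a plain butyl chain on the amide nitrogen or a 4-(dimethylamino)phenyl ring would help to separate. They also leave open how much of the step belongs to the ethoxy group, for which the matching amide with an unsubstituted phenyl ring and its amide hydrogen kept would be the direct comparison.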